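Aryl amine swap: benzothiophenyl in place of hydroxyquinolinyl

This account rests on a few compounds, and the source may have more. Where it says the series, first, only, none or still open, it means among the compounds named here.

Measured in a functional assay on DU-145 cells (Homo sapiens) for inhibition, read by trypan blue exclusion, with a stated time of 72 h; a lower number here means a stronger inhibitor, a higher number a weaker inhibitor:
compound 1 `Cn1c(=O)c(S(=O)(=O)c2ccc(F)cc2F)cc2cnc(Nc3cccc4[nH]ccc34)nc21` gives 750 nM
compound 2 `Cn1c(=O)c(S(=O)(=O)c2ccc(F)cc2F)cc2cnc(Nc3ccc4[nH]c(C(=O)O)cc4c3)nc21` gives 10000 nM
compound 3 `Cn1c(=O)c(S(=O)(=O)c2ccc(F)cc2F)cc2cnc(Nc3ccc4cccc(O)c4n3)nc21` gives 5000 nM

Compound 3 stands second highest of the three numbers; compound 2 is nearest, a 2.0-fold lower number from compound 2 to compound 3 (0.30 log units; within the scatter), and compound 1 furthest, a 6.7-fold higher number from compound 1 to compound 3 (0.82 log units; beyond the scatter). Compound 4 `Cn1c(=O)c(S(=O)(=O)c2ccc(F)cc2F)cc2cnc(Nc3ccc4sccc4c3)nc21` is not yet measured in this assay. It differs from compound 3 in one place: 1-benzothiophen-5-yl in place of 8-hydroxyquinolin-2-yl on a nitrogen on an aromatic ring.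

Among the measured compounds shown here, the steps that bear on this change all vary the same aryl group on the nitrogen of the shared core: a 13-fold higher number from compound 1 to compound 2 (1.12 log units; beyond the scatter) and a 6.7-fold higher number from compound 1 to compound 3 (0.82 log units; beyond the scatter) both move away from compound 1, whereas a 2.0-fold lower number from compound 2 to compound 3 (0.30 log units; within the scatter) stays within the scatter. The entering 1-benzothiophen-5-yl is, like the 1H-indol-4-yl of compound 1 at 750 nM, a bicycle without the carboxy of compound 2 or the hydroxy of compound 3. Compound 4 is therefore expected to give a lower number, a 3.3-fold lower number from compound 3 to compound 4 (0.52 log units; beyond the scatter). For compound 4 the estimate is 1500 nM, in the range 400 nM to 6000 nM.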

Compound 4, half-maximal inhibitory concentration: 500 nM
The estimate for compound 4 lay 3.0-fold (0.48 log units) above the measured number; the range from low to high includes it.
By their numbers in this assay, from the lowest: compounds 4 and 1 (each within the scatter of the next); then compounds 3 and 2 (each within the scatter of the next).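

In this assay the change to 1-benzothiophen-5-yl gives a 10-fold lower number from compound 3 to compound 4 (1.00 log units; beyond the scatter) and a 20-fold lower number from compound 2 to compound 4 (1.30 log units; beyond the scatter) in the second comparison, so a bicycle with neither the hydroxy of compound 3 nor the carboxy of compound 2 can reach the low end of the range at this nitrogen. The step of a 1.5-fold lower number from compound 1 to compound 4 (0.18 log units; within the scatter) leaves the two groups unresolved in this assay, which shows that the indole ring hydrogen of compound 1 is not required for a number of this size. No measurement shown here accounts for these steps.

Still open, as far as these compounds go, is whether an amine or a carboxylic acid on the 1-benzothiophen-5-yl would raise the number as far as the groups in compound 2 and compound 3 do. A single bicyclic ring such as plain phenyl in its place would show whether the second ring is needed at all.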